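Pyrrolopyridine, pyrazolopyridine and benzoxazolone acetamides on a shared core

This account rests on a few compounds, and the source may have more. Where it says the series, first, only, none or still open, it means among the compounds named here.

Compound 1 `CCOc1ncc(-c2nc(C(F)(F)F)sc2N2CCN(C(=O)Cn3ccc4cnccc43)[C@H](C)C2)cn1` and compound 2 `CCOc1ncc(-c2nc(C(F)(F)F)sc2N2CCN(C(=O)Cn3ncc4cccnc43)[C@H](C)C2)cn1` differ only in the bicyclic group on the saturated chain carbon bound to the carbonyl carbon. In an assay on blood for inhibition of C-X-C chemokine receptor type 3 (Homo sapiens), with a stated time of 30 min (on this read-out lower numbers stand for stronger inhibition and higher numbers for weaker inhibition), compound 1 gives 25 nM and compound 2 gives 372 nM. Compound 2 therefore stands with the highest number of the two; its nearest neighbour is compound 1, reached by a 15-fold higher number from compound 1 to compound 2 (1.17 log units; beyond the scatter).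

Compound 3 `CCOc1ncc(-c2nc(C(F)(F)F)sc2N2CCN(C(=O)Cn3c(=O)oc4ccccc43)[C@H](C)C2)cn1` carries the change (a group of 10 heavy atoms (7 carbon, 1 nitrogen, 2 oxygen; one five-membered aromatic ring with 2 hetero atoms, one six-membered aromatic ring of carbon only) in place of a group of 9 heavy atoms (6 carbon, 3 nitrogen; one five-membered aromatic ring with 2 hetero atoms, one six-membered aromatic ring with 1 hetero atom), on a saturated chain carbon bound to a carbonyl carbon). Within the data shown here, the only measured step that bears on it is the exchange of the bicyclic group at the same place, a 15-fold higher number from compound 1 to compound 2 (1.17 log units; beyond the scatter), which shows that this position responds strongly to a change of the bicycle. Among the measured compounds shown here, no measured pair shows a group with two oxygen atoms and a six-membered aromatic ring of carbon only, so the direction cannot be read from the series, only the scale. In this assay the step of a 1.9-fold lower number from compound 2 to compound 3 (0.27 log units; within the scatter) is expected, with wide uncertainty. For compound 3 the estimate in this assay is 200 nM, with a range from 30 nM to 1500 nM.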

Compound 3, half-maximal inhibitory concentration: 536 nM
For compound 3 the middle estimate is 2.7-fold (0.43 log units) below the measured one; measured number inside the range.
By their numbers in this assay, from the lowest: compound 1; then compounds 2 and 3 (each within the scatter of the next).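

With a 1.4-fold higher number from compound 2 to compound 3 (0.16 log units; within the scatter) inside the scatter, the groups of compound 2 and compound 3 cannot be told apart at this place, although one carries a six-membered aromatic ring with 1 hetero atom and the other a six-membered aromatic ring of carbon only. The large step seen earlier thus recurs with a second group, since a 21-fold higher number from compound 1 to compound 3 (1.33 log units; beyond the scatter) lies beyond the scatter, and among these three compounds only the group with a five-membered aromatic ring with 1 hetero atom gives the low number. Among these compounds, no compound here goes against that pattern, but it rests on a single compound on the favourable side.

The compounds shown leave open whether the five-membered ring alone decides the outcome, as compound 1 also differs from compound 3 in the six-membered ring and in the carbonyl. An indole, with one nitrogen and a six-membered aromatic ring of carbon only, would separate these two features, and an amine or a carboxylic acid on that ring would test how much further change this place tolerates. No independent data are available to explain these differences.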